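Chloro for methyl, second ester series

The source may report more compounds than this note shows. Statements on the series, on what has been measured and on what is new or still open speak of the compounds shown alone.

Compound 1 `COC(=O)c1c(-c2cc3ccccc3oc2=O)nn(-c2cccc(C)c2)c1C(=O)OC` and compound 2 `COC(=O)c1c(-c2cc3ccccc3oc2=O)nn(-c2cccc(Cl)c2)c1C(=O)OC` share one core; compound 3 `CCOC(=O)c1c(-c2cc3cc(OC)ccc3oc2=O)nn(-c2cccc(C)c2)c1C(=O)OCC` and compound 4 `CCOC(=O)c1c(-c2cc3cc(OC)ccc3oc2=O)nn(-c2cccc(Cl)c2)c1C(=O)OCC` share another. The difference between the two cores is not broken down here. In a functional assay on HeLa cells (Homo sapiens) for cytotoxicity, read by MTT assay, with a stated time of 48 h (on this read-out lower numbers stand for stronger inhibition and higher numbers for weaker inhibition), compound 1 gives 45000 nM, while compound 2 gives 76000 nM. The change between them is chloro in place of methyl on an aromatic carbon, and it made the step of a 1.7-fold higher number from compound 1 to compound 2 (0.23 log units; within the scatter). In this assay compound 3 gives 155000 nM, the highest number among the three measured compounds, beyond the scatter from both compound 1 and compound 2. Compound 4 differs from compound 3 by chloro in place of methyl on an aromatic carbon, the same change at the same place as between compound 1 and compound 2. The expectation for compound 4 is a step of a 1.7-fold higher number from compound 3 to compound 4 (0.22 log units; within the scatter). For the measured compounds named here, that expectation rests on the only precedent, the step of a 1.7-fold higher number from compound 1 to compound 2 (0.23 log units; within the scatter), and treats the second core as carrying it unchanged. For compound 4 the estimate in this assay is 260000 nM, with a range from 120000 nM to 550000 nM.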

Compound 4, half-maximal inhibitory concentration: 160000 nM
Estimate against measurement, compound 4: 1.6-fold (0.21 log units) above; low and high end bracket the measured number.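

In this assay, chloro in place of methyl on the second core gives a 1.0-fold higher number from compound 3 to compound 4 (0.01 log units; within the scatter), so on this core, as on the first, the step stays within the scatter. The two steps do not differ beyond what repeated measurement allows: the same change on two cores in this assay, a 1.7-fold higher number (0.23 log units; within the scatter) from compound 1 to compound 2 and a 1.0-fold higher number (0.01 log units; within the scatter) from compound 3 to compound 4, 1.6-fold (0.21 log units) apart, within the scatter of two such steps. For the compounds shown here, this supports carrying the change between these two cores in this one assay, but since neither step is beyond the scatter, it shows only that the exchange has no resolved effect on either core, not that a defined shift transfers from one core to the other.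

The compounds shown leave open whether a group such as an amine, a carboxylic acid or a longer chain in place of the methyl would give a step beyond the scatter on either core. They also leave open whether the exchange of methyl for chloro would stay within the scatter on a third core.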